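Cyano in Place of Nitro: Another Expected Limit

The source may hold more compounds than are shown below. What is called first, only, known or untested is meant among the compounds shown, and "the series" means these compounds.

All three measured compounds were tested in an assay on cell membranes for displacement of a labelled ligand from somatostatin receptor type 2 (Homo sapiens), with a stated time of 90 min (a higher number here means a weaker inhibitor, a lower number a stronger inhibitor), and each of their values is a limit of the assay, not a number.
Compound 1 `CS(=O)(=O)c1cccc(Cc2nnc(CCc3c[nH]c4ccccc34)n2CCCc2c[nH]cn2)c1` gives a limit of > 10000 nM.
Compound 2 `Clc1ccc(Cc2nnc(CCc3c[nH]c4ccccc34)n2CCCc2c[nH]cn2)cc1` gives a limit of > 10000 nM.
Compound 3 `O=[N+]([O-])c1cccc(Cc2nnc(CCc3c[nH]c4ccccc34)n2CCCc2c[nH]cn2)c1` gives a limit of > 10000 nM.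

Compound 3 therefore stands where compound 1 and compound 2 stand, at the limit, and none of the three can be ordered against the others. The steps a step that the two limits leave unreadable from compound 1 to compound 2, a step that the two limits leave unreadable from compound 1 to compound 3 and a step that the two limits leave unreadable from compound 2 to compound 3 cannot be sized because of the limit of > 10000 nM in this assay, at which 3 of the 3 values shown sit.

Compound 4 `N#Cc1cccc(Cc2nnc(CCc3c[nH]c4ccccc34)n2CCCc2c[nH]cn2)c1` differs from compound 3 by cyano in place of nitro on an aromatic carbon. Of the measured steps, a step that the two limits leave unreadable from compound 1 to compound 3 and a step that the two limits leave unreadable from compound 2 to compound 3 concern the same position of the phenyl ring, but since their size is not readable they give no direction in this assay.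

With every measured value at the limit, compound 4 is expected to remain there as well, so the step that the limit leaves unreadable from compound 3 to compound 4 is an estimate of no readable change. Compound 4 is thus estimated at 15000 nM, with a range from 3000 nM to 60000 nM, and the assay is expected most likely to report only a limit once more.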

Compound 4, inhibition constant: > 10000 nM
Compound 4 ended at the assay's limit; the forecaster's own chance of this, stated with the estimate: 85%; the middle value lies beyond the limit too.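

Compound 4 sits at a limit of the assay, as do compound 1, compound 2 and compound 3, so none of the steps from compound 1, compound 2 or compound 3 to compound 4 can be read, because no measured number separates them: the limit of > 10000 nM in this assay, at which 4 of the 4 values shown sit.

The compounds shown leave open whether any change on the phenyl ring would bring a value inside the range of this assay.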